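Swapping a phenylethenyl arm for a thiophene ring

A few compounds are considered here, and "the series" means these few. Any claim that something is new, unique, unknown or untested is made for them only; others in the source may bear on it.

Of the compounds shown here, three sharing one core have been tested in a functional assay on Ehrlich cells (Mus musculus) for antiproliferative activity, read by trypan blue exclusion, with a stated time of 2 h, tested at 25 ug/mL; on this read-out lower numbers stand for a weaker effect and higher numbers for a stronger effect at the one concentration tested. Compound 1 `N#CC1=C(N)N(c2ccc(S(N)(=O)=O)cc2)C2=C(C(=O)CCC2)C1c1ccccc1` gives 30%, compound 2 `N#CC1=C(N)N(c2ccc(S(N)(=O)=O)cc2)C2=C(C(=O)CCC2)C1/C=C/c1ccccc1` gives 10%, and compound 3 `N#CC1=C(N)N(c2ccc(S(N)(=O)=O)cc2)C2=C(C(=O)CCC2)C1c1ccc(Cl)cc1Cl` gives 50%. Compound 2 stands lowest of the three: the step of a number 20 percentage points lower from compound 1 to compound 2 (beyond the scatter) and the step of a number 40 percentage points higher from compound 2 to compound 3 (beyond the scatter) both run against it, and the step of a number 20 percentage points higher from compound 1 to compound 3 (beyond the scatter) separates the other two.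

The next compound, compound 4 `N#CC1=C(N)N(c2ccc(S(N)(=O)=O)cc2)C2=C(C(=O)CCC2)C1c1cccs1`, differs from compound 2 in one place: thiophen-2-yl in place of 2-phenylethenyl on a saturated ring carbon. Both measured steps that start from the 2-phenylethenyl group of compound 2 bear on this change. Each puts an aromatic ring, phenyl or 2,4-dichlorophenyl, on the saturated ring carbon, and each raises the number in this assay, by a modest amount for compound 1 and a large amount for compound 3. Thiophen-2-yl is also an aromatic ring on that carbon, so a rise is expected for compound 4, of about a number 20 percentage points higher from compound 2 to compound 4 (beyond the scatter). The estimate for compound 4 is 30%, ranging from 10% to 55%.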

Compound 4, a percentage reported as activity, at one concentration (the size of the read-out at that concentration, not a potency): 80%
The estimate for compound 4 lay 50 percentage points below the measured number, outside the stated range (above it).
By their numbers in this assay, from the lowest: compound 2; then compound 1; then compound 3; then compound 4.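

At this saturated ring carbon, the kind of aromatic ring matters, not just the presence of one: in this assay the thiophen-2-yl group outdoes phenyl, with a number 50 percentage points higher from compound 1 to compound 4 (beyond the scatter), and also outdoes 2,4-dichlorophenyl, with a number 30 percentage points higher from compound 3 to compound 4 (beyond the scatter). Chlorine atoms on a phenyl ring are therefore not needed for the highest number in this series, and a number 70 percentage points higher from compound 2 to compound 4 (beyond the scatter) is the widest gap among the compounds shown. No measurement here explains why this five-membered ring with a sulfur atom stands highest.

Going by these compounds, whether the sulfur atom, the five-membered ring or the point of attachment carries the rise remains open. Furan-2-yl, which has oxygen in place of sulfur, and thiophen-3-yl, which is attached through a different ring carbon, would help separate these possibilities.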